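The compounds below may be only part of what the source reports. "The series", "measured", "known", "first", "only" and "open" are said of these compounds alone.

Series of triazine hydrazones carrying a sulfamoylanilino and an anilino group on the shared core. Compound 1 `NS(=O)(=O)c1ccc(Nc2nc(N/N=C/c3ccc(C(F)(F)F)cc3)nc(Nc3ccccc3)n2)cc1` is measured in a functional assay on MDA-MB-468 cells (Homo sapiens) for inhibition, read by sulforhodamine B assay, with a stated time of 48 h (on this read-out higher numbers stand for weaker inhibition of growth and lower numbers for stronger inhibition of growth), and gives 1730 nM. Compound 2 `Cc1nn(-c2ccccc2)cc1/C=N/Nc1nc(Nc2ccccc2)nc(Nc2ccc(S(N)(=O)=O)cc2)n1` gives 1520 nM in this assay; the step of a 1.1-fold lower number from compound 1 to compound 2 (0.06 log units; within the scatter) shows that the two aryl groups on the carbon with a double bond to nitrogen are not told apart by the data. On the numbers in hand compound 2 has the lowest value of the two, but it sits within the scatter of compound 1, so no order between them can be claimed.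

Compound 3 `NS(=O)(=O)c1ccc(Nc2nc(N/N=C/c3ccccn3)nc(Nc3ccccc3)n2)cc1` has not yet been measured. It differs from compound 2 in one place: pyridin-2-yl in place of 3-methyl-1-phenyl-1H-pyrazol-4-yl on a carbon with a double bond to nitrogen. Going by the values given here, the only measured step that bears on this position is a 1.1-fold lower number from compound 1 to compound 2 (0.06 log units; within the scatter), which was within the scatter. Among the compounds with values here, no step with a pyridin-2-yl group at this carbon exists, so nothing beyond that one step can be drawn on. The expectation for this assay is therefore a step no larger than the scatter, in no preferred direction, giving a 1.1-fold higher number from compound 2 to compound 3 (0.05 log units; within the scatter). Compound 3 is accordingly estimated at 1700 nM, with a range from 700 nM to 4500 nM.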

Compound 3, concentration for 50% growth inhibition: 310 nM
Estimate against measurement, compound 3: 5.5-fold (0.74 log units) above, and the stated range ends above it.
By their numbers in this assay, from the lowest: compound 3; then compounds 2 and 1 (each within the scatter of the next).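

In this assay the carbon with a double bond to nitrogen turns out to be a position that can move the read-out: 4-(trifluoromethyl)phenyl and 3-methyl-1-phenyl-1H-pyrazol-4-yl could not be told apart, whereas pyridin-2-yl gives a 4.9-fold lower number from compound 2 to compound 3 (0.69 log units; beyond the scatter) and a 5.6-fold lower number from compound 1 to compound 3 (0.75 log units; beyond the scatter) in this series. Both steps lie beyond the scatter, so compound 3 stands clearly apart from the other two compounds, which remain level with each other. Nothing measured alongside these compounds accounts for the step.

Pyridin-2-yl differs from both earlier groups in more than one feature, so the compounds shown do not separate the effect of its ring nitrogen from that of its smaller size; an unsubstituted phenyl, pyridin-3-yl or pyridin-4-yl on this carbon would help to divide the two. On these data alone, it also remains open whether the step carries over when the rest of the molecule changes, for instance with a morpholine in place of the anilino group on the shared core.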